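Swapping a hydroxypropoxy for an aminopropylamino chain

A few compounds are considered here, and "the series" means these few. Any claim that something is new, unique, unknown or untested is made for them only; others in the source may bear on it.

Compound 3 `OCCCOc1cc2c(NC3CCCCC3)ncnc2cn1` gives 33 nM in a functional assay on CHO cells for antagonist activity at metabotropic glutamate receptor 1 (Rattus norvegicus), with a stated time of 5 min (a higher number here means a weaker inhibitor, a lower number a stronger inhibitor), the lowest number of the three compounds shown. Compound 2 `COCCOc1cc2c(NC3CCCCC3)ncnc2cn1` gives 101 nM and compound 1 `CN(C)c1cc2c(NC3CCCCC3)ncnc2cn1` gives 199 nM in this assay. The step of a 6.0-fold lower number from compound 1 to compound 3 (0.78 log units; beyond the scatter) and the step of a 3.1-fold lower number from compound 2 to compound 3 (0.49 log units; beyond the scatter) both favour compound 3, while the step of a 2.0-fold lower number from compound 1 to compound 2 (0.29 log units; within the scatter) is small.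

Compound 4 `NCCCNc1cc2c(NC3CCCCC3)ncnc2cn1` differs from compound 3 in one place: (3-aminopropyl)amino in place of 3-hydroxypropoxy on an aromatic carbon. Among the measured compounds shown here, no measured step covers either an amino linker in place of the ring oxygen or a terminal amine in place of the hydroxyl. The only nitrogen-linked group shown, the dimethylamino of compound 1, sits at the weak end, seen in the step of a 6.0-fold lower number from compound 1 to compound 3 (0.78 log units; beyond the scatter), and the step of a 3.1-fold lower number from compound 2 to compound 3 (0.49 log units; beyond the scatter) shows that the terminal hydroxyl mattered. For the measured compounds named here, with those hints but no direct precedent, a modest rise in the number is expected, as the step of a 2.1-fold higher number from compound 3 to compound 4 (0.33 log units; beyond the scatter). Compound 4 is therefore estimated at 70 nM in this assay, within a range from 15 nM to 300 nM.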

Compound 4, inhibition constant: 200 nM
Compound 4: middle estimate off by 2.9-fold (0.46 log units), on the low side; the measured number falls inside the stated range.
By their numbers in this assay, from the lowest: compound 3; then compounds 2, 1 and 4 (each within the scatter of the next).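

In this assay, putting (3-aminopropyl)amino in place of 3-hydroxypropoxy gives a 6.1-fold higher number from compound 3 to compound 4 (0.78 log units; beyond the scatter), so at this aromatic carbon, keeping the same number of heavy atoms in the chain is not enough to keep the low number of compound 3. The new chain also shows no real separation from the other two groups, with a 2.0-fold higher number from compound 2 to compound 4 (0.30 log units; within the scatter) and a 1.0-fold higher number from compound 1 to compound 4 (0.00 log units; within the scatter), which leaves 3-hydroxypropoxy as the only group shown that stands apart from the rest. Nothing available explains why this swap raises the number.

The swap changes both the atom linking the chain to the ring and the atom at the chain's end, so the loss cannot be assigned to either one. A 3-aminopropoxy chain or a 3-hydroxypropylamino chain, each changing only one of the two, would separate these effects.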